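The source may report more compounds than this note shows. Statements on the series, on what has been measured and on what is new or still open speak of the compounds shown alone.

Three compounds carrying the same bis(4-fluorophenyl)methylthioethylamine chain attached to a piperidine were measured in an assay on membranes from Cortex for displacement of a labelled ligand from Sigma non-opioid intracellular receptor 1 (Cavia porcellus), read by scintillation counting, with a stated time of 120 min; on this read-out lower numbers stand for stronger inhibition and higher numbers for weaker inhibition. Compound 1, `Fc1ccc(C(SCCNC2CCN(Cc3ccccc3)CC2)c2ccc(F)cc2)cc1`, gives 3.81 nM. Compound 2, `Fc1ccc(CN2CCC(NCCSC(c3ccc(F)cc3)c3ccc(F)cc3)CC2)cc1`, gives 13.3 nM. Compound 3, `O=C(c1ccccc1F)N1CCC(NCCSC(c2ccc(F)cc2)c2ccc(F)cc2)CC1`, gives 3.57 nM.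

Two steps among the measured compounds are informative. The change fluoro in place of hydrogen on an aromatic carbon produces a 3.5-fold higher number from compound 1 to compound 2 (0.54 log units; beyond the scatter). The change (2-fluorophenyl)carbonyl in place of benzyl on an amine nitrogen in a ring produces a 1.1-fold lower number from compound 1 to compound 3 (0.03 log units; within the scatter), so compounds 1 and 3 sit within the usual scatter of each other. Between compounds 2 and 3 the difference is a 3.7-fold lower number from compound 2 to compound 3 (0.57 log units; beyond the scatter).

Compound 4, `O=C(c1ccc(F)cc1F)N1CCC(NCCSC(c2ccc(F)cc2)c2ccc(F)cc2)CC1`, has not been measured. It differs from compound 3 by fluoro in place of hydrogen on an aromatic carbon. For the measured compounds named here, this is the same kind of change as the one from compound 1 to compound 2, though the surroundings are not identical: in compound 4 the entering fluoro sits meta to a fluoro group (1 heavy atom) and para to a large group, whereas in compound 2 it sits only para to a large group, and the two cores differ in the way just described for compounds 1 and 3.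

Going by the values given here, the one precedent, a 3.5-fold higher number from compound 1 to compound 2 (0.54 log units; beyond the scatter), points toward a weakening on adding the fluoro, and compound 4 is therefore expected to show a step of a 2.4-fold higher number from compound 3 to compound 4 (0.38 log units; beyond the scatter) in this assay, with less confidence because the core is different. On that basis compound 4 is estimated at 8.5 nM, with a plausible range expected between 3.5 nM and 22 nM.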

Compound 4, inhibition constant: 20.6 nM
Estimate against measurement, compound 4: 2.4-fold (0.38 log units) below; low and high end bracket the measured number.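

In this assay, fluoro in place of hydrogen on the (2-fluorophenyl)carbonyl core gives a 5.8-fold higher number from compound 3 to compound 4 (0.76 log units; beyond the scatter) in this series, a weakening of the same direction as the one seen earlier on the benzyl core. Set side by side, the two steps cannot be told apart, so on these two cores the change carries over in direction and, as far as the scatter allows, in size: the same change on two cores in this assay, a 3.5-fold higher number (0.54 log units; beyond the scatter) from compound 1 to compound 2 and a 5.8-fold higher number (0.76 log units; beyond the scatter) from compound 3 to compound 4, 1.7-fold (0.22 log units) apart, within the scatter of two such steps. The comparison also fits the remaining new steps, with a 1.5-fold higher number from compound 2 to compound 4 (0.19 log units; within the scatter) leaving the two fluorinated compounds within the scatter of each other and a 5.4-fold higher number from compound 1 to compound 4 (0.73 log units; beyond the scatter) marking the full distance from the unfluorinated benzyl compound, but two pairs in one assay do not show that the step would hold on any other core, and they give no reason for it.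

The compounds shown leave open whether chloro or methoxy in place of the entering fluoro would bring a step of the same direction and size. They also leave open whether the step would survive on a core with a longer chain in place of the thioethyl chain.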